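The compounds below may be only part of what the source reports. "The series", "measured", "known", "first", "only" and "open" are said of these compounds alone.

Series notes. For the measured compounds named here, compound 1 `CN1CCN(CCCN(C[C@H]2Cc3ccccc3CN2)[C@H]2CCCc3cccnc32)CC1` holds the lowest of the two numbers measured so far in a functional assay on CCRF-CEM cells for antagonist activity at C-X-C chemokine receptor type 4 (Homo sapiens), read by calcium flux, with stated times of 25 min and 90 s; a lower number here means a stronger inhibitor, a higher number a weaker inhibitor: compound 1 gives 125 nM. Compound 2 `c1cnc2c(c1)CCC[C@@H]2N(CCCN1CCNCC1)Cc1nc2ccccc2s1` in this assay gives 1200 nM, a gap from compound 1 that lies beyond the scatter, but the two structures differ in several places at once, so no single step can be read from this pair. Compound 3 `c1ccc2c(c1)CN[C@@H](CN(CCC1CCNCC1)[C@H]1CCCc3cccnc31)C2` is not yet measured and differs from compound 1 in one place only: piperidin-4-yl in place of (4-methylpiperazin-1-yl)methyl on a saturated chain carbon, two bonds along the chain from an amine nitrogen. Going by the values given here, no measured pair isolates this change, so nothing in the data fixes its direction or size. A modest loss is expected, with the step of a 2.4-fold higher number from compound 1 to compound 3 (0.38 log units; beyond the scatter) judged as probably just beyond the scatter rather than large. Compound 3 is estimated at 300 nM in this assay, within a range of 90 nM to 1000 nM.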

Compound 3, half-maximal inhibitory concentration: 150 nM
Compound 3: middle estimate off by 2.0-fold (0.30 log units), on the high side; the range from low to high includes it.
By their numbers in this assay, from the lowest: compounds 1 and 3 (each within the scatter of the next); then compound 2.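

At the saturated chain carbon two bonds along the chain from an amine nitrogen, piperidin-4-yl in place of (4-methylpiperazin-1-yl)methyl gives a 1.2-fold higher number from compound 1 to compound 3 (0.08 log units; within the scatter) in this assay, so the two compounds cannot be told apart here. This position therefore accepts both a ring with 2 hetero atoms and 0 hydrogen-bond donors and a ring with 1 hetero atom and 1 hydrogen-bond donor, at least on the core of compound 1. No measurement bears on why this exchange leaves the read-out within the scatter.

Still open, going by these compounds, is whether a ring nitrogen is needed on this side chain at all, which cyclohexyl or morpholin-4-yl in the same place would test. Also open, on these data alone, is how a longer chain carrying the piperidin-4-yl ring would read.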